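Cytotoxicity of piperidinone bis-arylidenes: trifluoromethyl to fluoro

The source may report more compounds than this note shows. Statements on the series, on what has been measured and on what is new or still open speak of the compounds shown alone.

Measured in an ADME assay on L02 cells (Homo sapiens) for cytotoxicity, read by MTT assay, with a stated time of 24 h; a lower number here means a stronger inhibitor, a higher number a weaker inhibitor:
compound 1 `CN1C/C(=C\c2ccncc2)C(=O)/C(=C/c2ccccc2F)C1` gives 14900 nM;
compound 2 `CN1C/C(=C\c2ccncc2)C(=O)/C(=C/c2ccccc2C(F)(F)F)C1` gives 15800 nM;
compound 3 `O=C1/C(=C/c2ccncc2)CN(S(=O)(=O)c2ccc(C(F)(F)F)cc2)C/C1=C\c1ccccc1F` gives 18600 nM.

Compounds 1 and 2 share a core; compound 3 has a different one, and the difference between the two cores is not broken down here. The three values lie within the usual scatter of one another.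

Compound 4 `O=C1/C(=C/c2ccncc2)CN(S(=O)(=O)c2ccc(F)cc2)C/C1=C\c1ccccc1F` is not yet measured. It differs from compound 3 by fluoro in place of trifluoromethyl on an aromatic carbon. The same kind of change runs from compound 2 to compound 1, (fluoro in place of trifluoromethyl on an aromatic carbon), with the place para to a large group in the one case and ortho to a large group in the other. In this assay that step was a 1.1-fold lower number from compound 2 to compound 1 (0.03 log units; within the scatter).

Resting on that step, the step from compound 3 to compound 4 is expected to be a 1.1-fold lower number from compound 3 to compound 4 (0.04 log units; within the scatter). Compound 4 is estimated at 17000 nM, between 9000 nM and 34000 nM.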

Compound 4, half-maximal inhibitory concentration: 15600 nM
Estimate against measurement, compound 4: 1.1-fold (0.04 log units) above; the measured number falls inside the stated range.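

In this assay fluoro in place of trifluoromethyl gives a 1.2-fold lower number from compound 3 to compound 4 (0.08 log units; within the scatter) and (4-fluorophenyl)sulfonyl in place of methyl on the ring amine nitrogen gives a 1.0-fold higher number from compound 1 to compound 4 (0.02 log units; within the scatter) so neither change moves the number measurably. With every step inside the scatter, the series gives no sign that the core alters this change, but it cannot show that a step of real size would carry over, and it rests on two cores only. The change reads alike on both cores: the same change on two cores in this assay, a 1.1-fold lower number (0.03 log units; within the scatter) from compound 2 to compound 1 and a 1.2-fold lower number (0.08 log units; within the scatter) from compound 3 to compound 4, 1.1-fold (0.05 log units) apart, within the scatter of two such steps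

Still open, on these data alone, is whether an amine or a carboxylic acid in place of fluoro on these aromatic rings would move the number beyond the scatter. Also open, as far as these compounds go, is whether a longer chain on the ring nitrogen would do so.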